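The source may report more compounds than this note shows. Statements on the series, on what has been measured and on what is new or still open speak of the compounds shown alone.

Measured compounds:
- compound 1 `COc1ccc(-c2c(-c3cc(OC)c(OC)c(OC)c3)ssc2=S)cc1[N+](=O)[O-]`: 38200 nM
- compound 2 `COc1ccc(-c2c(-c3cc(OC)c(OC)c(OC)c3)ssc2=S)cc1N`: 2170 nM
- compound 3 `COc1ccc(-c2ssc(=O)c2-c2cc(OC)c(OC)c(OC)c2)cc1[N+](=O)[O-]`: 22300 nM

All three were tested in a functional assay on KB cells (Homo sapiens) for antiproliferative activity, read by MTT assay, with a stated time of 72 h; a lower number here means a stronger inhibitor, a higher number a weaker inhibitor. Compound 1 and compound 2 share one core; compound 3 and the unmeasured compound 4 `COc1ccc(-c2ssc(=O)c2-c2cc(OC)c(OC)c(OC)c2)cc1N` share another. The difference between the two cores is not broken down here.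

Within the first pair a single change was made: amino in place of nitro on an aromatic carbon The step it made was an 18-fold lower number from compound 1 to compound 2 (1.25 log units; beyond the scatter). Compound 3 sits close to compound 1 in this assay, and its gap to compound 2 lies beyond the scatter.

Among the measured compounds shown here, compound 4 differs from compound 3 by the same change, at the same kind of place: amino in place of nitro on an aromatic carbon Since this is the same change, made on a compound whose value is near that of compound 1, the step from compound 3 to compound 4 is expected to resemble the one from compound 1 to compound 2, though a single earlier example gives only a rough guide. The expected step is a 12-fold lower number from compound 3 to compound 4 (1.09 log units; beyond the scatter), resting on the step of an 18-fold lower number from compound 1 to compound 2 (1.25 log units; beyond the scatter) and on the value of compound 3, 22300 nM. Compound 4 is therefore estimated to give 1800 nM in this assay, with a likely range from 500 nM to 7000 nM.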

Compound 4, half-maximal inhibitory concentration: 60 nM
Estimate against measurement, compound 4: 30-fold (1.48 log units) above, and the stated range ends above it.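

In this assay the swap of nitro for amino gave a 370-fold lower number from compound 3 to compound 4 (2.57 log units; beyond the scatter) and so pointed the same way as it did on the core of compound 1. The direction of the change carried over, but its size did not, and the two steps lie further apart than repeated measurements would explain: the same change on two cores in this assay, an 18-fold lower number (1.25 log units; beyond the scatter) from compound 1 to compound 2 and a 370-fold lower number (2.57 log units; beyond the scatter) from compound 3 to compound 4, 21-fold (1.32 log units) apart, beyond the scatter of two such steps. A step seen on one core is therefore a guide to direction here and not a number that can simply be transferred, yet two pairs are too few to make a rule, and these data do not show why the step is larger on the core of compound 3.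

The compounds shown leave open whether the large gain needs the amino group itself or would also appear with another group at that place, such as a hydroxyl, a methylamino group or an acetamide. They also leave open whether the same swap would give a step of similar size on any further core, so each new core would need its own measured pair.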